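Working notes: 4-methylphenyl to 4-methoxyphenyl step

The source may report more compounds than this note shows. Statements on the series, on what has been measured and on what is new or still open speak of the compounds shown alone.

Values in a functional assay on T47D cells (Homo sapiens) for cytotoxicity, read by MTT assay, with a stated time of 3 h; a higher number here means a weaker inhibitor, a lower number a stronger inhibitor:
- compound 1 `O=C(CN1CCN(c2cc(=O)[nH]c3ccc(F)cc23)CC1)Nc1nc(-c2ccccc2)cs1` gives 7200 nM
- compound 2 `O=c1cc(N2CCNCC2)c2cc(F)ccc2[nH]1` gives 37700 nM
- compound 3 `Cc1ccc(-c2csc(NC(=O)CN3CCN(c4cc(=O)[nH]c5ccc(F)cc45)CC3)n2)cc1` gives 8410 nM

Compound 3 stands close to compound 1, the two values lying within the scatter of each other. Compound 2 stands apart from compound 3 with a higher number, a gap beyond the scatter.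

The next compound is compound 4 `COc1ccc(-c2csc(NC(=O)CN3CCN(c4cc(=O)[nH]c5ccc(F)cc45)CC3)n2)cc1`, which carries methoxy in place of methyl on an aromatic carbon, para to a large group. This turns the 4-methylphenyl into 4-methoxyphenyl: methoxy in place of methyl on an aromatic carbon.

Going by the values given here, only one measured step bears on this carbon, a 1.2-fold higher number from compound 1 to compound 3 (0.07 log units; within the scatter), where methyl replaced hydrogen. That step stays within the scatter. Compound 2 is not joined to the others by a step in one place, so it offers no guide here. Among the compounds with values here, no methoxy compound has been measured in this assay, so the support is thin and the range is kept wide. No change beyond the scatter is expected for this replacement. The expected step is a 1.1-fold lower number from compound 3 to compound 4 (0.02 log units; within the scatter). For compound 4 the estimated value is 8000 nM, with an expected range of 4500 nM to 15000 nM.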

Compound 4, half-maximal inhibitory concentration: 16900 nM
Compound 4: the middle estimate sits 2.1-fold (0.32 log units) below what was measured; the measured number lies above the stated range.
By their numbers in this assay, from the lowest: compounds 1, 3 and 4 (each within the scatter of the next, the first and the last beyond it); then compound 2.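

In this assay, the aromatic carbon para to a large group now gives its first step beyond the scatter: methoxy in place of hydrogen gives a 2.3-fold higher number from compound 1 to compound 4 (0.37 log units; beyond the scatter), a modest step, whereas methyl in place of hydrogen gave a 1.2-fold higher number from compound 1 to compound 3 (0.07 log units; within the scatter). The direct replacement of methyl by methoxy, a 2.0-fold higher number from compound 3 to compound 4 (0.30 log units; within the scatter), stays within the scatter, so at this carbon the methoxy compound is separated from the hydrogen compound but not from the methyl compound. No measured evidence on the origin of this difference is available for the series.

Going by these compounds, with only hydrogen, methyl and methoxy represented at this carbon, it remains open whether a hydroxyl, an amine or a carboxylic acid there would give a step beyond the scatter from compound 1 and in which direction. Also open, on these data alone, is whether any group at this carbon can bring the number clearly under that of compound 1, 7200 nM, in this assay.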